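The source may hold more compounds than are shown below. What is called first, only, known or untested is meant among the compounds shown, and "the series" means these compounds.

Among the compounds with values here, compound 2, `Cc1cccc(NC(=O)N[C@@H](C)c2ccccc2)c1`, gives 100% in an ADME assay on the whole organism with Oryza sativa as the target, tested at 10 uM (on this read-out lower numbers stand for a stronger effect and higher numbers for a weaker effect at the one concentration tested), the highest of the three numbers measured so far. Its enantiomer compound 1, `Cc1cccc(NC(=O)N[C@H](C)c2ccccc2)c1`, gives 47% in this assay, and the step of a number 53 percentage points higher from compound 1 to compound 2 (beyond the scatter) is large; that step rests on (the fact that compounds 1 and 2 differ only in the configuration as drawn). Compound 3, `CC(C)c1ccccc1NC(=O)N[C@@H](C)c1ccccc1`, gives 93% in this assay, a number that lies within the scatter of the value of compound 2, so the two cannot be told apart.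

Compound 4, `C[C@H](NC(=O)Nc1cccc(C(F)(F)F)c1)c1ccccc1`, has not yet been measured in this assay. It differs from compound 2 in one place: trifluoromethyl in place of methyl on an aromatic carbon. Within the data shown here, the one measured step, from compound 1 to compound 2, concerns only the configuration at the saturated chain carbon and says nothing about a change on the aromatic ring, so no measured step bears directly on this exchange. The values of compound 2 and compound 3 show that two different groups on that ring both give numbers near the top of the scale. Compound 4 is therefore expected to show a step of a number 8 percentage points lower from compound 2 to compound 4 (within the scatter), that is, no step beyond the scatter. The estimate for compound 4 in this assay is 92%, with a range from 70% to 100%.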

Compound 4, a percentage reported as activity, at one concentration (the size of the read-out at that concentration, not a potency): 92%
Compound 4: the middle estimate sits on the measured number at the digits printed, within the range that was stated.
By their numbers in this assay, from the lowest: compound 1; then compounds 4, 3 and 2 (each within the scatter of the next).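

In this assay, trifluoromethyl in place of methyl on an aromatic carbon, meta to a large group, gives a number 8 percentage points lower from compound 2 to compound 4 (within the scatter). Within the data shown here, this is the first step read on the aromatic ring itself, as the only earlier step concerned configuration at the saturated chain carbon, and it shows that at this position four heavy atoms in place of one leave a number that cannot be told apart from that of compound 2. Nothing at hand explains why this exchange leaves the read-out within the scatter.

The compounds shown leave open whether the same exchange would also stay within the scatter in the configuration of compound 1, which gives 47%, the one number here that stands clearly apart from its enantiomer. They also leave open whether a group of another kind on this aromatic carbon, such as an amine or a carboxylic acid, would give a step beyond the scatter from compound 2.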